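Bromo for Chloro: A Second Halogen Swap Examined

The compounds below may be only part of what the source reports. "The series", "measured", "known", "first", "only" and "open" are said of these compounds alone.

Compound 1, `O=C(O)CCc1ccc(OCC2COc3ccc(Cl)cc3O2)cc1F`: 50%
Compound 2, `O=C(O)CCc1ccc(OCC2COc3ccc(Br)cc3O2)cc1F`: 81%
Compound 3, `CC#C[C@@H](CC(=O)O)c1ccc(OC[C@H]2COc3cc(Cl)c(Cl)cc3O2)cc1`: 33%

Of the compounds shown here, three have been measured in a functional assay on HEK293 cells for agonist activity at Free fatty acid receptor 1 (Homo sapiens), read by fluorescence and calcium flux, with a stated time of 10 min; on this read-out higher numbers stand for larger maximal responses and lower numbers for smaller maximal responses. Compound 1 gives 50%, and compound 2 gives 81%. Compound 2 differs from compound 1 by bromo in place of chloro on an aromatic carbon, and that single change made a step of a number 31 percentage points higher from compound 1 to compound 2 (beyond the scatter). Compound 3 gives 33% and stands lowest of the three measured compounds; its core differs from the shared core of compound 1 and compound 2, but the difference between the two cores is not broken down here.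

The unmeasured compound 4, `CC#C[C@@H](CC(=O)O)c1ccc(OC[C@H]2COc3cc(Br)c(Cl)cc3O2)cc1`, differs from compound 3 by bromo in place of chloro on an aromatic carbon. Going by the values given here, this is the same kind of change as the one from compound 1 to compound 2, though not the same: in compound 4 the carbon that carries the new bromo group is also ortho to a chloro group, which is not the case in compound 2. Because a number 31 percentage points higher from compound 1 to compound 2 (beyond the scatter) was large and beyond the scatter, the author expects the swap to raise the maximal response of compound 4 as well, though the different surroundings of the changed carbon leave the size less certain. The step expected from compound 3 to compound 4 in this assay is a number 22 percentage points higher from compound 3 to compound 4 (beyond the scatter). Compound 4 is therefore estimated at 55%, with a range from 35% to 75%.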

Compound 4, largest response reached (Emax), in percent of the reference or control that the assay uses: 82%
For compound 4 the middle estimate is 27 percentage points below the measured one; the measured number lies above the stated range.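

In this assay, the same swap of bromo for chloro on an aromatic carbon gave a number 49 percentage points higher from compound 3 to compound 4 (beyond the scatter), so the change raised the maximal response on the core of compound 3 as it had on the shared core of compound 1 and compound 2. The direction of the change therefore carried from one core to the other in these two pairs, but its size did not: the same change on two cores in this assay, a number 31 percentage points higher (beyond the scatter) from compound 1 to compound 2 and a number 49 percentage points higher (beyond the scatter) from compound 3 to compound 4, 18 percentage points apart, beyond the scatter of two such steps. These two pairs do not show what sets the size of the step, since the cores differ in more than one place and the changed carbon in compound 4 is also ortho to a chloro group, so the core and the local surroundings cannot be separated here, nor can a rule be drawn for other cores in the series.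

The compounds shown leave open how iodo, fluoro or a methyl group on the same aromatic carbon would compare with bromo in this read-out. Going by these compounds alone, they also leave open whether bromo in place of the other chloro group of compound 3, the one that stays in compound 4, would give a step of similar size.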